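The compounds below may be only part of what the source reports. "The series", "measured", "known", "first", "only" and "open" are said of these compounds alone.

Compound 3, `O=C(NC[C@@H]1C[C@@H]2C=C[C@@H]1C2)NS(=O)(=O)N1CCC(CCNC(=O)c2ccc3ccccc3n2)CC1`, is measured in a functional assay on the whole organism (blood) with Rattus norvegicus as the target, with stated times of 24 h and 1 h, at a dose of 5 mg/kg by the intraperitoneal route (a lower number here means a weaker effect, a higher number a stronger effect of the compound at the dose given), where compound 3 gives 21%. Among the three compounds measured so far it stands second highest. Compound 2, `O=C(NC[C@@H]1C[C@@H]2C=C[C@@H]1C2)NS(=O)(=O)N1CCC(CCNC(=O)c2nc3ccccc3s2)CC1`, gives 24% in this assay, and the step of a number 3 percentage points lower from compound 2 to compound 3 (within the scatter) lies within the scatter. Compound 1, `COc1ccncc1C(=O)NCCC1CCN(S(=O)(=O)NC(=O)NC[C@@H]2C[C@@H]3C=C[C@@H]2C3)CC1`, gives 14% in this assay, and the step of a number 7 percentage points higher from compound 1 to compound 3 (within the scatter) is also within the scatter, as is a number 10 percentage points higher from compound 1 to compound 2 (within the scatter). The three compounds therefore cannot be told apart on these numbers.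

Compound 4, `Cn1cc(C(=O)NCCC2CCN(S(=O)(=O)NC(=O)NC[C@@H]3C[C@@H]4C=C[C@@H]3C4)CC2)c(=O)n(C)c1=O`, differs from compound 3 only at the group on the carbonyl carbon whose other neighbour is an amide-type nitrogen: a group of 10 heavy atoms (6 carbon, 2 nitrogen, 2 oxygen; one six-membered aromatic ring with 2 hetero atoms) in place of a group of 10 heavy atoms (9 carbon, 1 nitrogen; one six-membered aromatic ring of carbon only, one six-membered aromatic ring with 1 hetero atom), on a carbonyl carbon. Going by the values given here, every measured step so far concerns the very same position, and each of them, a number 10 percentage points higher from compound 1 to compound 2 (within the scatter), a number 7 percentage points higher from compound 1 to compound 3 (within the scatter) and a number 3 percentage points lower from compound 2 to compound 3 (within the scatter), stayed within the scatter. On this basis no step beyond the scatter is expected in this assay for the change from compound 3 to compound 4, so the expected step is a number 1 percentage points lower from compound 3 to compound 4 (within the scatter). Among the compounds with values here, the estimate for compound 4 in this assay is therefore 20%, with a range from 8% to 32%, since the entering group has no measured precedent here and the range must stay wide.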

Compound 4, a percentage reported as activity, at one dose (the size of the read-out at that dose, not a potency): 23%
Compound 4: the middle estimate sits 3 percentage points below what was measured; the range from low to high includes it.
By their numbers in this assay, from the lowest: compounds 1, 3, 4 and 2 (each within the scatter of the next).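

In this assay, the group with one six-membered aromatic ring with 2 hetero atoms and 2 double bonds outside aromatic rings gives a number 2 percentage points higher from compound 3 to compound 4 (within the scatter), while the comparisons with the other two compounds give a number 1 percentage points lower from compound 2 to compound 4 (within the scatter) and a number 9 percentage points higher from compound 1 to compound 4 (within the scatter). This extends the earlier picture at the carbonyl carbon to a group of a different kind, with 4 hydrogen-bond acceptors in place of the 1 of quinolin-2-yl, and with a single ring in place of two; even this change of group leaves all four compounds within the scatter of one another, so the position has not yet shown a step beyond the scatter at the dose given. Nothing on hand explains why these compounds cannot be told apart in this read-out.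

As far as these compounds go, whether a group of a different type on the carbonyl carbon, such as a carboxylic acid, a primary amine or a plain methyl, would give a step beyond the scatter remains open. The compounds shown also share the rest of their structure, so they leave open what a change elsewhere, such as a longer chain in the shared core, would do to the effect.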